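This account rests on a few compounds, and the source may have more. Where it says the series, first, only, none or still open, it means among the compounds named here.

In a functional assay on HSC-4 cells (Homo sapiens) for cytotoxicity, with a stated time of 24 h (on this read-out lower numbers stand for higher toxicity in this test and higher numbers for lower toxicity in this test), compound 2 `O=C1/C(=C/c2ccccc2)CCC/C1=C\c1cccc([N+](=O)[O-])c1` gives 2400 nM and compound 3 `O=C1/C(=C/c2ccc(Cl)cc2)CCC/C1=C\c1cccc([N+](=O)[O-])c1` gives 2300 nM, so the two stand level within the scatter. Compound 1 `CN(C)c1ccc(/C=C2\CCC/C(=C\c3ccccc3[N+](=O)[O-])C2=O)cc1` gives > 400000 nM, which is a limit of the assay and not a number. Compound 4 `CN(C)c1ccc(/C=C2\CCC/C(=C\c3cccc([N+](=O)[O-])c3)C2=O)cc1` arises from compound 3 by dimethylamino in place of chloro on an aromatic carbon, with dimethylamino in place of chloro on an aromatic carbon. Among the measured compounds shown here, the one measured step, a 1.0-fold lower number from compound 2 to compound 3 (0.02 log units; within the scatter), put chloro in place of hydrogen and stayed within the scatter, so it does not size this change. Compound 1 also carries dimethylamino, and its > 400000 nM is a limit. A move to a higher number in this assay is therefore expected, and the expected step is an 8.7-fold higher number from compound 3 to compound 4 (0.94 log units; beyond the scatter). For compound 4 the estimated value is 20000 nM, with an expected range of 3000 nM to 200000 nM.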

Compound 4, half-maximal cytotoxic concentration: 71000 nM
For compound 4 the middle estimate is 3.6-fold (0.55 log units) below the measured one; measured number inside the range.
By their numbers in this assay, from the lowest: compounds 3 and 2 (each within the scatter of the next); then compound 4. At a limit, above all of these: compound 1.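

In this assay this position proved sensitive to the group it carries: dimethylamino in place of chloro gave a 31-fold higher number from compound 3 to compound 4 (1.49 log units; beyond the scatter), and dimethylamino in place of hydrogen gave a 30-fold higher number from compound 2 to compound 4 (1.47 log units; beyond the scatter), whereas chloro in place of hydrogen had stayed within the scatter. With dimethylamino kept, 3-nitrophenyl in place of 2-nitrophenyl gave an at least 5.6-fold lower number from compound 1 to compound 4 (0.75 log units; beyond the scatter). Compound 1 stands at a limit and not at a number: the limit of > 400000 nM in this assay, at which 1 of the 4 values shown sits. The compounds shown leave open whether the rise belongs to dimethylamino alone or would also come with a primary amine or a methoxy group on this carbon.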